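This account rests on a few compounds, and the source may have more. Where it says the series, first, only, none or still open, it means among the compounds named here.

Measured so far in a functional assay on RAW264.7 cells (Mus musculus) for inhibition (on this read-out lower numbers stand for stronger inhibition and higher numbers for weaker inhibition), are these compounds:
- compound 1 `CCOC(=O)C1=CCCCC1S(=O)(=O)Nc1ccc(Cl)cc1F` at 160 nM
- compound 2 `CCOC(=O)C1=CCCCC1S(=O)(=O)Nc1ccccc1F` at 75 nM
- compound 3 `CCOC(=O)C1=CCCCC1S(=O)(=O)Nc1ccccc1CC` at 130 nM

Compound 2 has the best-placed number of the set only against compound 1 (a 2.1-fold lower number from compound 1 to compound 2 (0.33 log units; beyond the scatter)), a modest step beyond the scatter. Compound 3 cannot be separated from it (a 1.7-fold higher number from compound 2 to compound 3 (0.24 log units; within the scatter)).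

The next change leads to compound 4 `CCOC(=O)C1=CCCCC1S(=O)(=O)Nc1nccs1` and is described by 1,3-thiazol-2-yl in place of 2-fluorophenyl on a sulfonamide nitrogen as 1,3-thiazol-2-yl in place of 2-fluorophenyl on a sulfonamide nitrogen.

Both measured steps bear on this only indirectly. Each swaps a single group on an aromatic carbon and moves the number little (a 2.1-fold lower number from compound 1 to compound 2 (0.33 log units; beyond the scatter) and a 1.7-fold higher number from compound 2 to compound 3 (0.24 log units; within the scatter)). For the measured compounds named here, no measured compound replaces the whole aromatic ring, so the data fix neither size nor direction firmly. A larger step than either is therefore expected, and a higher number is the tentative direction. The expected change is a 5.3-fold higher number from compound 2 to compound 4 (0.73 log units; beyond the scatter) in this assay on this reasoning. For compound 4 the estimated value is 400 nM with a wide expected range (from 100 nM to 3000 nM)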

Compound 4, half-maximal inhibitory concentration: > 10000 nM
Compound 4: only a limit was reported (the forecaster's own chance of this, stated with the estimate: 10%); middle value at least 25-fold (1.39 log units) from the limit.
By their numbers in this assay, from the lowest: compounds 2, 3 and 1 (each within the scatter of the next, the first and the last beyond it). At a limit, above all of these: compound 4.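

Swaps of a single group on an aromatic carbon moved the number in this assay only a little, but replacing the whole group on the sulfonamide nitrogen gives an at least 130-fold higher number from compound 2 to compound 4 (2.12 log units; beyond the scatter) as the first large step in the series. The number at this position therefore holds through the substituent changes seen on the phenyl ring, yet does not hold when 1,3-thiazol-2-yl takes the place of 2-fluorophenyl. The reading for compound 4 is a limit and not a number: the limit of > 10000 nM in this assay, at which 1 of the 4 values shown sits.

The compounds shown leave open whether the large step goes with the loss of the six-membered ring of carbon only or with the entry of the ring nitrogen and sulfur. A pyridin-2-yl group on the sulfonamide nitrogen would help to separate these two readings.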